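Notes on the group on the ring nitrogen

The source may hold more compounds than are shown below. What is called first, only, known or untested is meant among the compounds shown, and "the series" means these compounds.

Measured so far in an assay on membranes from brain for displacement of a labelled ligand from Sigma non-opioid intracellular receptor 1 (Cavia porcellus), read by scintillation counting, with a stated time of 90 min; a lower number here means a stronger inhibitor, a higher number a weaker inhibitor:
compound 1 `COc1cccc(-n2cc(C(=O)NCCCCN3CCc4cc(OC)c(OC)cc4C3)nn2)c1` gives 20200 nM
compound 2 `COc1ccccc1Cn1cc(C(=O)NCCCCN2CCc3cc(OC)c(OC)cc3C2)nn1` gives 20600 nM

Compound 1 holds the lowest of the two numbers in this assay, but its nearest neighbour compound 2 sits within the scatter of it, so no order between the two can be claimed. Within the data shown here, the only measured step, a 1.0-fold higher number from compound 1 to compound 2 (0.01 log units; within the scatter), exchanged the group on the ring nitrogen for a benzyl carrying its methoxy elsewhere and left the number unchanged beyond the scatter.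

Compound 3 `COc1cc2c(cc1OC)CN(CCCCNC(=O)c1cn(Cc3cccc(O)c3)nn1)CC2` arises from compound 1 by 3-hydroxybenzyl in place of 3-methoxyphenyl on an aromatic nitrogen. Among the measured compounds shown here, the benzyl insertion already tested in the step from compound 1 to compound 2 bears on this change and was flat; the free hydroxyl in place of methoxy has no measured precedent here. The expectation is therefore a step of about a 1.0-fold lower number from compound 1 to compound 3 (0.00 log units; within the scatter), none beyond the scatter. Compound 3 is estimated at 20000 nM in this assay, with a range from 7000 nM to 60000 nM.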

Compound 3, inhibition constant: 8080 nM
For compound 3 the middle estimate is 2.5-fold (0.39 log units) above the measured one; measured number inside the range.
By their numbers in this assay, from the lowest: compound 3; then compounds 1 and 2 (each within the scatter of the next).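

At this position the group on the aromatic nitrogen can now move the number in this assay: 3-hydroxybenzyl gives a 2.5-fold lower number from compound 1 to compound 3 (0.40 log units; beyond the scatter) and a 2.5-fold lower number from compound 2 to compound 3 (0.41 log units; beyond the scatter), both modest but beyond the scatter, whereas the earlier exchange gave only a 1.0-fold higher number from compound 1 to compound 2 (0.01 log units; within the scatter). Of the three groups, only the 3-hydroxybenzyl of compound 3 counts a hydrogen-bond donor, and compound 3 alone stands apart from the other two numbers, though a single compound establishes no pattern. No measurement bears on the origin of this step.

Each step to compound 3 changes more than one feature of the group, so the contributions of the hydroxyl, its ring position and the benzyl link stay unresolved. A 3-methoxybenzyl or 2-hydroxybenzyl group would separate these, while a 3-aminobenzyl group would test whether another substituent at that ring position matches the hydroxyl.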